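The source may report more compounds than this note shows. Statements on the series, on what has been measured and on what is new or still open speak of the compounds shown alone.

The measured compounds and their values in a functional assay on PANC-1 cells (Homo sapiens) for inhibition, read by MTT assay, with a stated time of 24 h, tested at 10 uM; a higher number here means more inhibition at the concentration tested (going by the name of the read-out), a lower number less inhibition:

compound 1 `COc1ccccc1NC(=O)Oc1cc(=O)n(CCCO)c2c1CC(CC=C(C)C)C(C)(C)C2`, compound 1 gives 0%
compound 2 `CC(C)=CCC1Cc2c(OC(=O)Nc3cccc(F)c3)cc(=O)n(CCCO)c2CC1(C)C`, compound 2 gives 0%
compound 3 `CC(C)=CCC1Cc2c(OC(=O)Nc3ccc(Cl)cc3)cc(=O)n(CCCO)c2CC1(C)C`, compound 3 gives 0%

Compound 3 stands level with compounds 1 and 2 in this assay; the steps of no change at the digits printed from compound 1 to compound 2 (within the scatter), no change at the digits printed from compound 1 to compound 3 (within the scatter) and no change at the digits printed from compound 2 to compound 3 (within the scatter) all lie within the scatter, so none of the three carbamate aryl groups separates itself from the others. The next compound, compound 4 `CC(C)=CCC/C(C)=C/CC1Cc2c(OC(=O)Nc3ccc(Cl)cc3)cc(=O)n(CCCO)c2CC1(C)C`, keeps the 4-chlorophenyl carbamate of compound 3 and changes only the chain: 3-methylbut-2-en-1-yl in place of hydrogen on a saturated chain carbon bound to a double-bonded chain carbon. Among the compounds with values here, no measured step touches this chain; the three measured steps all concern the aryl group on the amide-type nitrogen and were each within the scatter. Within the data shown here, they therefore give no direction for the chain extension, and the only guide is that compound 3 itself shows no inhibition. Among the measured compounds shown here, compound 4 is accordingly expected to remain close to compound 3, with a step of a number 5 percentage points higher from compound 3 to compound 4 (within the scatter) of little size, though with wide uncertainty because no measured pair informs it. The estimate for compound 4 in this assay is 5%, in the range 0% to 30%.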

Compound 4, a percentage reported as inhibition, at one concentration (the size of the read-out at that concentration, not a potency): 4.3%
Estimate against measurement, compound 4: 0.7 percentage points above, and the stated range covers the measured number.
By their numbers in this assay, from the lowest: compounds 1, 2, 3 and 4 (each within the scatter of the next).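

In this assay, the chain gains its first reading: 3-methylbut-2-en-1-yl in place of hydrogen on a saturated chain carbon bound to a double-bonded chain carbon gives a number 4.3 percentage points higher from compound 3 to compound 4 (within the scatter). The earlier steps shown here concerned only the aryl group on the amide-type nitrogen, whereas this one shows that the 3,7-dimethylocta-2,6-dien-1-yl chain does not separate itself from the 3-methylbut-2-en-1-yl chain when the 4-chlorophenyl group is kept. Nothing at hand offers an explanation for this result.

On these data alone, whether an amine or a carboxylic acid in place of the 3-methylbut-2-en-1-yl group would read differently remains open. So does whether the 3,7-dimethylocta-2,6-dien-1-yl chain would give the same reading with the 2-methoxyphenyl or 3-fluorophenyl group on the amide-type nitrogen.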